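This account rests on a few compounds, and the source may have more. Where it says the series, first, only, none or still open, it means among the compounds named here.

Three compounds share one core, a piperazine urea carrying a chlorophenoxy-benzyl arm, and differ only in the aromatic group on the urea nitrogen. In an assay on isolated protein for inhibition of Fatty-acid amide hydrolase 1 (Homo sapiens), with a stated time of 60 min (a higher number here means a weaker inhibitor, a lower number a stronger inhibitor), compound 1 `O=C(Nc1cccc2nonc12)N1CCN(Cc2cccc(Oc3ccc(Cl)cc3)c2)CC1` gives 28 nM, compound 2 `O=C(Nc1cccc2cn[nH]c12)N1CCN(Cc2cccc(Oc3ccc(Cl)cc3)c2)CC1` gives 1300 nM, and compound 3 `Cc1nc2cc(NC(=O)N3CCN(Cc4cccc(Oc5ccc(Cl)cc5)c4)CC3)ccc2o1` gives 7.7 nM. Compound 3 thus stands lowest of the three numbers: the step of a 3.6-fold lower number from compound 1 to compound 3 (0.56 log units; beyond the scatter) is modest, while a 170-fold lower number from compound 2 to compound 3 (2.23 log units; beyond the scatter) is large, as is a 46-fold higher number from compound 1 to compound 2 (1.67 log units; beyond the scatter). Swapping this one aromatic group therefore moves this assay by amounts that range, across these three steps, from modest to large.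

Compound 4 `O=C(Nc1cncc2ccccc12)N1CCN(Cc2cccc(Oc3ccc(Cl)cc3)c2)CC1` continues the series with isoquinolin-4-yl in place of 2-methyl-1,3-benzoxazol-5-yl on an amide-type nitrogen. Among the measured compounds shown here, no measured pair makes exactly this exchange, so the three steps above are the only guide, and they show that a new bicyclic group on this nitrogen can land close to compound 3 or far from it. Because compound 1, with no hydrogen-bond donor on its bicyclic group, gives 28 nM, a number in that region seems the most likely outcome, with a wide margin on either side. Compound 4 is therefore expected to come in at about 50 nM in this assay, between 8 nM and 400 nM, which would be a step of a 6.5-fold higher number from compound 3 to compound 4 (0.81 log units; beyond the scatter).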

Compound 4, half-maximal inhibitory concentration: 6.7 nM
Beside the measured number, compound 4's estimate is 7.5-fold (0.87 log units) above it; the whole stated range lies above it.
By their numbers in this assay, from the lowest: compounds 4 and 3 (each within the scatter of the next); then compound 1; then compound 2.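

In this assay, the step of a 1.1-fold lower number from compound 3 to compound 4 (0.06 log units; within the scatter) shows that the urea nitrogen takes isoquinolin-4-yl, with its two six-membered aromatic rings, as readily as 2-methyl-1,3-benzoxazol-5-yl, with its five-membered ring, its oxygen and its methyl group, so none of these features is needed to reach this level. Among the compounds shown here, the other two steps, a 4.2-fold lower number from compound 1 to compound 4 (0.62 log units; beyond the scatter) and a 190-fold lower number from compound 2 to compound 4 (2.29 log units; beyond the scatter), show that a third kind of bicyclic group also keeps clear of compound 1 and lies far from compound 2, which leaves the 1H-indazol-7-yl group of compound 2 as the one group that stands well apart from the rest. Nothing in the data offers a reason for these differences.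

The compounds shown leave open whether a second ring is needed at all, a question that a single ring such as phenyl or pyridin-3-yl on the same nitrogen would address. They also leave open whether the ring nitrogen of isoquinolin-4-yl contributes anything, which the all-carbon naphthalen-1-yl group would test.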